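Working notes: from bromo to phenoxy on the aryl end

A few compounds are considered here, and "the series" means these few. Any claim that something is new, unique, unknown or untested is made for them only; others in the source may bear on it.

Measured in a functional assay on PC-3 cells (Homo sapiens) for cytotoxicity, read by MTT assay, with a stated time of 48 h; a lower number here means a stronger inhibitor, a higher number a weaker inhibitor:
- compound 1 `Cc1cccc(/C=C/[C@](C)(O)CC[C@@H]2[C@@]3(C)CCCC(C)(C)[C@@H]3CC[C@@]2(C)O)c1C`: 3500 nM
- compound 2 `CC1(C)CCC[C@]2(C)[C@@H](CC[C@@](C)(O)/C=C/c3ccc(Br)cc3)[C@](C)(O)CC[C@@H]12`: 41300 nM

Among the compounds with values here, compound 2 holds the higher of the two numbers, and its only neighbour is compound 1. The next structure is compound 3 `CC1(C)CCC[C@]2(C)[C@@H](CC[C@@](C)(O)/C=C/c3ccc(Oc4ccccc4)cc3)[C@](C)(O)CC[C@@H]12`, described by phenoxy in place of bromo on an aromatic carbon, para to a large group.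

Within the data shown here, one measured step bears on this change: a 12-fold higher number from compound 1 to compound 2 (1.07 log units; beyond the scatter). It is large and beyond the scatter, and it shows that a change at this aryl end can move the number in this assay. Among the measured compounds shown here, no measured compound carries phenoxy, so this step informs the size more than the direction. A moderate move towards a lower number is expected, though a rise is not excluded. The expected step is a 1.9-fold lower number from compound 2 to compound 3 (0.27 log units; within the scatter). For compound 3 the estimate is 22000 nM, with an expected range of 6000 nM to 80000 nM.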

Compound 3, half-maximal inhibitory concentration: 268 nM
Compound 3: middle estimate off by 82-fold (1.91 log units), on the high side; the whole stated range lies above it.
By their numbers in this assay, from the lowest: compound 3; then compound 1; then compound 2.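

In this assay the change from bromo to phenoxy, on an aromatic carbon para to a large group, gives a 150-fold lower number from compound 2 to compound 3 (2.19 log units; beyond the scatter) and so fixes a direction at this place for one named group. The earlier step, a 12-fold higher number from compound 1 to compound 2 (1.07 log units; beyond the scatter), showed only that the aryl end can move the number, whereas this step shows that a lower number can come with a much larger entering group: seven heavy atoms for one, including a six-membered aromatic ring of carbon only. No measurement at hand accounts for the size of this step.

From the compounds shown here alone, whether the lower number depends on the oxygen link or on the second aromatic ring stays open, and a directly bound phenyl or a benzyl group at the same place would separate the two. Also open, going by these compounds, is how an amine or a carboxylic acid on the outer ring of the phenoxy group would read.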